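The compounds below may be only part of what the source reports. "The series", "measured", "known", "first", "only" and "open" are said of these compounds alone.

Measured compounds:
- compound 1, `COC(=O)COc1cccc(-n2cnc(-c3ccccc3)c2-c2ccccc2)c1`: 6500 nM
- compound 2, `CCc1nc(-c2ccccc2)c(-c2ccccc2)n1CCCCCCCC(=O)OC`: 31 nM
- compound 3, `CCOC(=O)CC(C)CCCCCn1c(C)nc(-c2ccccc2)c1-c1ccccc1`: 130 nM

In an assay on H4 cells for inhibition of Fatty-acid amide hydrolase 1 (Homo sapiens) (a lower number here means a stronger inhibitor, a higher number a weaker inhibitor), compound 3 gives 130 nM. That is the second highest of the three numbers. Its nearest neighbour is compound 2, which in this assay gives 31 nM, a lower number and a gap that lies beyond the usual scatter of repeated measurements. The furthest is compound 1, which in this assay gives 6500 nM, a far higher number and by a wide margin the weakest inhibitor among the three.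

Compound 4, `CCOC(=O)CC(CCCCCn1c(C)nc(-c2ccccc2)c1-c1ccccc1)C(C)C`, has not been measured. It differs from compound 3 in one place: isopropyl in place of methyl on a saturated chain carbon bound to two saturated chain carbons. Both compounds keep the same core and the same ethyl ester at the end of the chain.

Among the compounds with values here, no pair among the measured compounds differs only in this way, so there is no directly comparable step to lean on. The change is a small enlargement of a branch on the saturated chain, with no change in donors, acceptors or charge. Compound 4 is therefore expected to stay close to compound 3, with a step of a 1.2-fold higher number from compound 3 to compound 4 (0.06 log units; within the scatter) that is not expected to clearly exceed the scatter in either direction. The estimate for compound 4 in this assay is 150 nM, within a range of 50 nM to 500 nM.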

Compound 4, half-maximal inhibitory concentration: > 100000 nM
Compound 4 was reported as a limit (the forecaster's own chance of this, stated with the estimate: 2%); middle value at least 660-fold (2.82 log units) from the limit.
By their numbers in this assay, from the lowest: compound 2; then compound 3; then compound 1. At a limit, above all of these: compound 4.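

In this assay, within the data shown here, isopropyl in place of methyl on a saturated chain carbon bound to two saturated chain carbons gives an at least 760-fold higher number from compound 3 to compound 4 (2.88 log units; beyond the scatter), the first step in this set between compounds that differ in one place. It shows that this chain carbon is far from indifferent to what it carries: the exchange of methyl for isopropyl adds no donor, acceptor, ring or charge, yet it separates a compound with a measurable value from one without. Compound 4 is reported only as a limit, > 100000 nM, so the step has a lower bound and no upper one: the limit of > 100000 nM in this assay, at which 1 of the 4 values shown sits.

The compounds shown do not tell whether an ethyl group or a plain hydrogen on this carbon would give a number close to that of compound 3 or would also end at the limit, so the point at which the value collapses remains unlocated. They also leave open whether the same isopropyl would have this effect with a carboxylic acid in place of the ethyl ester, or on a longer chain.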